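A few compounds are considered here, and "the series" means these few. Any claim that something is new, unique, unknown or untested is made for them only; others in the source may bear on it.

In an ADME assay for permeability, using PAMPA (on this read-out higher numbers stand for higher permeability and lower numbers for lower permeability), compound 1 (`Cc1ccc(O)c(C(=O)Nc2ccc([N+](=O)[O-])cc2Cl)c1`) gives 134 10^-6 cm/s and compound 3 (`O=C(Nc1ccccc1C(F)(F)F)c1cc(Cl)ccc1O`) gives 26 10^-6 cm/s while compound 2 (`N#Cc1ccc(NC(=O)c2cc(Cl)ccc2O)c(Cl)c1`) gives 5.1 10^-6 cm/s and so stands lowest of the three, beyond the usual scatter of repeat measurements from both of the others. These three compounds differ from one another in more than one place, so their numbers cannot be pinned on any single structural change.

Compound 4 (`CC(=O)Nc1ccc(NC(=O)c2cc(Cl)ccc2O)c(Cl)c1`) has acetamido in place of cyano on an aromatic carbon, meta to a chloro group and para to a large group, a change counted as acetamido in place of cyano on an aromatic carbon in the two structures. It is the kind of single swap that medicinal chemists like to compare, since only one place differs. For the measured compounds named here, no measured pair here shows this swap or anything close to it, so what follows is a judgement and not a reading from the data.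

In this assay a modest fall is expected, near the edge of the scatter. The expected step is a 2.3-fold lower number from compound 2 to compound 4 (0.37 log units; beyond the scatter) and it could well prove smaller or larger. For compound 4 the estimated value is 2.2 10^-6 cm/s with a likely range from 0.6 10^-6 cm/s to 8 10^-6 cm/s in this wide estimate.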

Compound 4, apparent permeability: 87 10^-6 cm/s
Compound 4: the middle estimate sits 40-fold (1.60 log units) below what was measured, and the stated range ends below it.
By their numbers in this assay, from the lowest: compound 2; then compound 3; then compounds 4 and 1 (each within the scatter of the next).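

In this assay, for the compounds shown here, the one change of acetamido in place of cyano gives a 17-fold higher number from compound 2 to compound 4 (1.23 log units; beyond the scatter) and offers the first clean comparison at this aromatic carbon, meta to a chloro group and para to a large group. The earlier compounds shown here differed in several places at once, so they could not show that this single position can move the read-out by a large step on its own. The entering acetamido group has 4 heavy atoms against 2 for cyano and brings 1 hydrogen-bond donor where cyano has none, yet in this one pair those additions came with a higher number, not a lower one, though nothing measured here gives a reason for the size of the step.

From the compounds shown here alone, whether the rise is particular to acetamido remains open, as a single pair cannot show how other groups at this place, such as an amine, a carboxylic acid or a methoxy group, would compare. Going by these compounds, it is equally open whether the same swap would give a step of similar size on a different core, such as that of compound 1, which carries a nitro group at this place.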